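Cyclohexyl in Place of a Silicon Chain on a Furan-Fused Core

A few compounds are considered here, and "the series" means these few. Any claim that something is new, unique, unknown or untested is made for them only; others in the source may bear on it.

Measured so far:
compound 1, `CCOC(=O)CNc1oc2c(C)ncc(CO)c2c1Nc1ccccn1`, "not active" (no number reported) in a functional assay on HEK293 cells for agonist activity at Toll-like receptor 8 (Homo sapiens), read by reporter gene assay; a higher number here means that more compound is needed for the effect, a lower number that less compound is needed
compound 2, `CCCCCNc1oc2c(C)ncc(CO)c2c1Nc1cccc(F)c1`, 370 nM
compound 3, `Cc1ncc(CO)c2c(Nc3ccccn3)c(NC[Si](C)(C)C)oc12`, 4990 nM

The three measured compounds share one core and differ in the group carried on the ring nitrogen and in the aromatic amine on the other side. Compound 1 gave no number, only a report of no activity. Compound 3 stands at the highest of the two numbers; the nearest entry, compound 2, sits at a far lower number, and that gap is beyond the usual scatter. Among the compounds with values here, no single-change step between measured compounds exists, so nothing here says how much one group swap is worth on its own.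

Compound 4, `Cc1ncc(CO)c2c(Nc3ccccn3)c(NC3CCCCC3)oc12`, differs from compound 3 in one place: a group of 6 heavy atoms (6 carbon; one six-membered non-aromatic ring of carbon only) in place of a group of 5 heavy atoms (4 carbon, 1 silicon; no ring), on a nitrogen on an aromatic ring. Within the data shown here, with no measured step to lean on, the expectation rests on the numbers alone: compound 2, with a plain carbon chain at that nitrogen, sits low, so a carbon ring at the same nitrogen is expected to move the number down rather than up, though by an uncertain amount. The step from compound 3 to compound 4 is estimated at a 3.3-fold lower number from compound 3 to compound 4 (0.52 log units; beyond the scatter). For compound 4 the expected value in this assay is 1500 nM, within a range from 300 nM to 7000 nM.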

Compound 4, half-maximal effective concentration: 6930 nM
For compound 4 the middle estimate is 4.6-fold (0.66 log units) below the measured one; the range from low to high includes it.
By their numbers in this assay, from the lowest: compound 2; then compounds 3 and 4 (each within the scatter of the next).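

In this assay, putting cyclohexyl in place of the silicon-bearing chain, on a nitrogen on an aromatic ring, gives a 1.4-fold higher number from compound 3 to compound 4 (0.14 log units; within the scatter). Within the data shown here, this is the first single-change step at this position, and it cannot tell the two compounds apart: an open chain holding a silicon atom and a six-membered ring of carbon only give numbers that agree within the usual variation between repeats. The silicon atom is therefore not required for a measurable number in this pair, as compound 4 has none and still gives one, but no measurement shown here explains why the exchange makes so little difference.

The two groups at this nitrogen leave open what a cyclopentyl ring, a longer carbon chain such as hexyl, or a chain ending in an amine would give with the same aromatic amine on the other side. From the compounds shown here alone, compound 2 differs from compound 3 and compound 4 in two places, so how much of its number comes from either place also remains open.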